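Benzyl-piperazine sulfonamides on the shared core: halophenyl to pyridyl

The compounds below may be only part of what the source reports. "The series", "measured", "known", "first", "only" and "open" are said of these compounds alone.

Three measured compounds share the core and the sulfonamide-linked piperidine or piperazine bearing a substituted benzyl group. In an assay on HEK293 cells for displacement of a labelled ligand from adenosine receptor A2b (Homo sapiens) (on this read-out higher numbers stand for weaker inhibition and lower numbers for stronger inhibition), compound 1 `CCn1c(=O)c2[nH]c(-c3ccc(S(=O)(=O)NC4CCN(Cc5ccc(F)cc5)CC4)cc3)cc2n(CC)c1=O` gives 12 nM, compound 3 `CCCn1c(=O)n(C)c(=O)c2[nH]c(-c3ccc(S(=O)(=O)N4CCN(Cc5cccc(F)c5)CC4)cc3)cc21` gives 17 nM, and compound 2 `Cn1c(=O)c2[nH]c(-c3ccc(S(=O)(=O)N4CCN(Cc5ccc(Br)cc5)CC4)cc3)cc2n(C)c1=O` gives 1 nM. Compound 2 holds the lowest number of the three, and its gaps to compound 1 and to compound 3 both lie beyond the scatter, so compound 2 stands as the most potent compound measured here.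

Compound 4 `Cn1c(=O)c2[nH]c(-c3ccc(S(=O)(=O)N4CCN(Cc5ccncc5)CC4)cc3)cc2n(C)c1=O` is not yet measured in this assay. It differs from compound 2 only in one place: pyridin-4-yl in place of 4-bromophenyl on a saturated chain carbon bound to an amine nitrogen in a ring. Within the data shown here, no measured pair isolates this kind of change, so no step can be drawn from the numbers at hand. The expectation is that the step from compound 2 to compound 4 in this assay will be a loss of potency of moderate size, an 8.0-fold higher number from compound 2 to compound 4 (0.90 log units; beyond the scatter), set mainly by the strong starting point of compound 2 at 1 nM. On that basis compound 4 is estimated at 8 nM, within a range from 2 nM to 40 nM.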

Compound 4, half-maximal inhibitory concentration: 27 nM
Estimate against measurement, compound 4: 3.4-fold (0.53 log units) below; low and high end bracket the measured number.
By their numbers in this assay, from the lowest: compound 2; then compounds 1, 3 and 4 (each within the scatter of the next, the first and the last beyond it).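

In this assay, among these compounds, the step with pyridin-4-yl in place of 4-bromophenyl on a saturated chain carbon bound to an amine nitrogen in a ring is a 27-fold higher number from compound 2 to compound 4 (1.43 log units; beyond the scatter), the first step that isolates a single place, and it shows that potency depends strongly on the group held there. The change removes the bromine and brings in a ring nitrogen together, so this one step cannot divide the loss between those two differences. Nothing at hand bears on the cause of the step.

A plain phenyl group at the same place would help separate the two differences, depending on whether its value falls closer to compound 2 or to compound 4. Also open, going by these compounds, is whether the same change gives a step of similar size on the piperidine sulfonamide of compound 1.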